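Amide variation in the series: notes ahead of compound 4

The source may report more compounds than this note shows. Statements on the series, on what has been measured and on what is new or still open speak of the compounds shown alone.

Measured so far in a functional assay on PC-3 cells (Homo sapiens) for cytotoxicity, read by XTT assay, with a stated time of 72 h; on this read-out lower numbers stand for stronger inhibition and higher numbers for weaker inhibition:
- compound 1 `O=C1C=CC(=O)C(c2cc(-c3ccc(C(=O)N4CCCCC4)s3)on2)=C1` gives > 30000 nM, a limit of the assay.
- compound 2 `COc1ccc(OC)c(-c2cc(-c3ccc(C(=O)N(C)Cc4ccccc4)s3)on2)c1` gives > 30000 nM, a limit of the assay.
- compound 3 `COc1ccc(OC)c(-c2cc(-c3ccc(C(=O)N4CCCCC4)s3)on2)c1` gives > 30000 nM, a limit of the assay.

Compound 3 thus stands only at a limit, as the limit of > 30000 nM in this assay, at which 3 of the 3 values shown sit, shows for every value in this assay. Within the data shown here, the single step between compounds differing in one place, a step that the two limits leave unreadable from compound 2 to compound 3, has no readable size, both ends being limits. Compound 4 `COc1ccc(OC)c(-c2cc(-c3ccc(C(=O)NC4CC4)s3)on2)c1` differs from compound 3 by cyclopropylamino in place of piperidin-1-yl on a carbonyl carbon. Among the measured compounds shown here, no measured step gives a readable size or direction for this change, so nothing in the numbers points to a gain. Compound 4 is therefore expected to stay at the limit, estimated at 30000 nM within 10000 nM to 100000 nM. That estimate means an expected step of a number no higher from compound 3 to compound 4 (the limit leaves the size open), effectively none.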

Compound 4, half-maximal inhibitory concentration: 7800 nM
Compound 4: middle estimate off by 3.8-fold (0.59 log units), on the high side; measured number below the stated range.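

In this assay, the amide position gives its first readable change: an at least 3.8-fold lower number from compound 3 to compound 4 (0.58 log units; beyond the scatter), and likewise an at least 3.8-fold lower number from compound 2 to compound 4 (0.58 log units; beyond the scatter). Compound 4 is the only amide shown that keeps the amide hydrogen, and that hydrogen changes together with the ring size in this one step. Both sizes stay open-ended because compound 2 and compound 3 each sit at a limit: the limit of > 30000 nM in this assay, at which 3 of the 4 values shown sit.

Going by these compounds, whether the amide hydrogen or the small ring carries the change remains open; a cyclohexylamino or a dimethylamino group on the same carbonyl carbon would help separate the two. Also open, on these data alone, is how cyclopropylamino reads on the core of compound 1.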